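A few compounds are considered here, and "the series" means these few. Any claim that something is new, unique, unknown or untested is made for them only; others in the source may bear on it.

Within the data shown here, in an ADME assay on MCF7 cells (Homo sapiens) for cytotoxicity, read by MTT assay, with a stated time of 48 h (on this read-out higher numbers stand for weaker inhibition and lower numbers for stronger inhibition), compound 1 `Fc1ccc2c(Cn3ccnc3)c(-c3ccc(Cl)cc3)[nH]c2c1` gives 45000 nM, the only true number so far. Compound 2 `COc1ccc(-c2[nH]c3cc(F)ccc3c2Cn2ccnc2)cc1` reads > 1000000 nM, which is a limit of the assay. Compound 3 `COc1ccc(-c2[nH]c3cc(Cl)ccc3c2Cn2ccnc2)cc1` reads > 1000000 nM, again a limit. Compound 2 thus has no exact place on the scale. Methoxy in place of chloro on an aromatic carbon brought a large change, an at least 22-fold higher number from compound 1 to compound 2 (1.34 log units; beyond the scatter), while chloro in place of fluoro on an aromatic carbon gave a step that the two limits leave unreadable from compound 2 to compound 3. Compound 4 `COc1ccc(-c2[nH]c3cc(F)ccc3c2Cn2cncn2)cc1` differs from compound 2 elsewhere: 1H-1,2,4-triazol-1-yl in place of 1H-imidazol-1-yl on a saturated chain carbon bound to an aromatic carbon. Neither measured step touches this place, so neither gives a size for the swap of 1H-imidazol-1-yl for 1H-1,2,4-triazol-1-yl. Compound 4 keeps the methoxy group of compound 2, which sits at the limit of > 1000000 nM in this assay, at which 2 of the 3 values shown sit, so no step beyond the scatter is expected in this assay, and another reading at the limit is likely. The expected change is a number no higher from compound 2 to compound 4 (the limit leaves the size open). Compound 4 is estimated at 1000000 nM, with an expected range of 300000 nM to 3000000 nM.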

Compound 4, half-maximal inhibitory concentration: 325000 nM
For compound 4 the middle estimate is 3.1-fold (0.49 log units) above the measured one; the measured number falls inside the stated range.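

In this assay, the swap of 1H-imidazol-1-yl for 1H-1,2,4-triazol-1-yl on a saturated chain carbon bound to an aromatic carbon gives an at least 3.0-fold lower number from compound 2 to compound 4 (0.48 log units; beyond the scatter). Among these compounds, this place, which no earlier step touched, therefore moves the read-out even with the methoxy group kept, and compound 4 gives a true number on that methoxy background. The real size of the step stays open because compound 2 holds only a limit of the assay: the limit of > 1000000 nM in this assay, at which 2 of the 4 values shown sit.

The compounds shown do not tell whether the same swap would act alike with the chloro group of compound 1 in place of the methoxy group. They also leave open how an amine or a carboxylic acid would read in place of the 1H-1,2,4-triazol-1-yl group at this place.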